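The compounds below may be only part of what the source reports. "The series", "measured", "known", "first", "only" and "open" are said of these compounds alone.

Measured so far:
- compound 1, `O=C(O)[C@@H]1NCC=C[C@@H]1O`: 14%
- compound 2, `O=C(O)[C@H]1NC[C@H](O)[C@@H](O)[C@@H]1O`: 43%

Both compounds were tested in an assay on isolated protein for inhibition of cytosolic endo-beta-N-acetylglucosaminidase (Homo sapiens), tested at 1000 uM; a higher number here means more inhibition at the concentration tested (going by the name of the read-out), a lower number less inhibition. Compound 1 gives 14% there, while compound 2 gives 43%. Of these two numbers compound 2 stands highest; its nearest neighbour is compound 1, whose number lies lower by a margin that is beyond the usual scatter of repeated measurements.

The next compound, compound 3, `O=C(O)[C@@H]1NC[C@@H](O)[C@H](O)[C@@H]1O`, keeps every atom and bond of compound 2. The change is this: the two compounds have the same atoms and bonds and differ only in configuration as drawn: 3 of 4 stereo elements differ; a stereocentre at a saturated ring carbon is drawn S in compound 2 and R in compound 3; a stereocentre at a saturated ring carbon is drawn S in compound 2 and R in compound 3; a stereocentre at a saturated ring carbon is drawn R in compound 2 and S in compound 3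

Among the compounds with values here, only two measured compounds are available, and no step between a pair of them differing in one place exists, so the size of a step from a change in configuration alone is not known from these data. Because compound 2 gives 43% and three of its four stereocentres are redrawn in compound 3, a drop in this assay is expected, of moderate size and possibly beyond the scatter; the expected step is a number 18 percentage points lower from compound 2 to compound 3 (beyond the scatter). Compound 3 is therefore estimated at 25%, within a range from 5% to 55%.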

Compound 3, a percentage reported as inhibition, at one concentration (the size of the read-out at that concentration, not a potency): 0.8%
Compound 3: middle estimate off by 24.2 percentage points, on the high side, and the stated range ends above it.
By their numbers in this assay, from the lowest: compound 3; then compound 1; then compound 2.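

In this assay, the change in configuration alone comes to a number 42.2 percentage points lower from compound 2 to compound 3 (beyond the scatter), so the arrangement in space at the saturated ring carbons clearly matters in this assay. The earlier compounds shown here could not show this, as compound 1 and compound 2 differ in more than one place. The loss can be assigned to configuration and not to any group entering or leaving, because of a single fact: the fact that compounds 2 and 3 differ only in the configuration as drawn.

Three stereocentres change together, and the compounds shown cannot tell whether one of them accounts for most of the step or whether the three share it. Also open, on these data alone, is how an amide or a methyl ester in place of the carboxylic acid would read out on the configuration of compound 2, the higher of the pair.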